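Ethyl Branching on the Chain of Compound 1

A few compounds are considered here, and "the series" means these few. Any claim that something is new, unique, unknown or untested is made for them only; others in the source may bear on it.

Compound 1 `Cc1cccc(C#CCSc2cccc(Cl)c2)n1` gives the lowest of the two numbers in a functional assay for inhibition of metabotropic glutamate receptor 5 (Homo sapiens), read by FLIPR and calcium flux (a lower number here means a stronger inhibitor, a higher number a weaker inhibitor), at 43 nM. Going by the values given here, compound 2 `Cc1cccc(C#CCSc2ccccc2)n1` gives 589 nM in this assay, and the step of a 14-fold higher number from compound 1 to compound 2 (1.14 log units; beyond the scatter) is the only measured step in this set. Compound 3 `Cc1cccc(C#CCNC(=O)Nc2cccc(Cl)c2)n1` reaches only a limit of this assay, > 10000 nM. Compound 4 `CCC(C#Cc1cccc(C)n1)Sc1cccc(Cl)c1` differs from compound 1 by ethyl in place of hydrogen on a saturated chain carbon bound to a sulfur and a triple-bonded carbon. Among the compounds with values here, no measured step touches this chain carbon; the step from compound 1 to compound 2 concerns the chloro group, which compound 4 keeps. In this assay the expectation is therefore a step of a 2.1-fold higher number from compound 1 to compound 4 (0.32 log units; beyond the scatter), close to the scatter and with wide uncertainty. Compound 4 is estimated at 90 nM, between 25 nM and 400 nM.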

Compound 4, half-maximal inhibitory concentration: 862 nM
Beside the measured number, compound 4's estimate is 9.6-fold (0.98 log units) below it; the measured number lies above the stated range.
By their numbers in this assay, from the lowest: compound 1; then compounds 2 and 4 (each within the scatter of the next). At a limit, above all of these: compound 3.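

Ethyl in place of hydrogen on the saturated chain carbon bound to a sulfur and a triple-bonded carbon gives a 20-fold higher number from compound 1 to compound 4 (1.30 log units; beyond the scatter) in this assay, so a change at this carbon weakens inhibition. This chain carbon thus joins the chloro group as a second place where a single change to compound 1 moves the number beyond the scatter. Nothing shown gives a cause for this step. On these data alone, whether methyl or hydroxyl on this carbon would cost as much stays open, as does whether ethyl has the same effect without the chloro group.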